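This account rests on a few compounds, and the source may have more. Where it says the series, first, only, none or still open, it means among the compounds named here.

Compound 1 `Cc1ncc([N+](=O)[O-])n1CCSC(=S)N1CCC(OC(=O)CN2CCCCC2)CC1` in an ADME assay on HeLa cells (Homo sapiens) for cytotoxicity (on this read-out lower numbers stand for stronger inhibition and higher numbers for weaker inhibition), gives 760 ug/mL.
Compound 2 `Cc1ncc([N+](=O)[O-])n1CCSC(=S)N1CCC(=O)CC1` in this assay reaches only the limit of the test, > 1000 ug/mL.
Compound 3 `Cc1ncc([N+](=O)[O-])n1CCSC(=S)N1CCC2(CC1)OCCO2` in this assay likewise reaches only the limit, > 1000 ug/mL.

Among these three, compound 1 is the only one with an actual number; the other two stop at the limit of > 1000 ug/mL in this assay, at which 2 of the 3 values shown sit, so nothing can be said about how far apart they really lie. Within the data shown here, no pair of measured compounds differs in just one place, so no measured step is available as a guide.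

Compound 4 `Cc1ncc([N+](=O)[O-])n1CCSC(=S)N1CCC(OC(=O)CCl)CC1` is not yet measured. It differs from compound 1 in a single spot: chloro in place of piperidin-1-yl on a saturated chain carbon bound to a carbonyl carbon.

Among the measured compounds shown here, with no comparable step to lean on, the expectation rests on the one number for compound 1 alone. For compound 4 in this assay a value of 400 ug/mL is expected, with a plausible range from 150 ug/mL to 1000 ug/mL. The expected step of a 1.9-fold lower number from compound 1 to compound 4 (0.28 log units; within the scatter) is a modest move towards stronger inhibition, only a little beyond the usual scatter, and a result at the limit of the test is also possible.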

Compound 4, half-maximal inhibitory concentration: 930 ug/mL
The estimate for compound 4 lay 2.3-fold (0.37 log units) below the measured number; the range from low to high includes it.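

In this assay, putting chloro in place of piperidin-1-yl on a saturated chain carbon bound to a carbonyl carbon gives a 1.2-fold higher number from compound 1 to compound 4 (0.09 log units; within the scatter). Among these compounds, this is the first measured change in a single place, and it shows that this read-out does not separate the two groups, even though a six-membered ring containing nitrogen leaves and a single chlorine atom enters. At this position, then, a measurable value does not depend on keeping the piperidin-1-yl ring.

From the compounds shown here alone, it remains open whether another group here, such as morpholin-4-yl, a primary amine or a longer carbon chain, would shift the number beyond the scatter. The upper end of the scale also offers little room, since values there are a limit and not a number: the limit of > 1000 ug/mL in this assay, at which 2 of the 4 values shown sit.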